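This account rests on a few compounds, and the source may have more. Where it says the series, first, only, none or still open, it means among the compounds named here.

In a functional assay on RXF 393 cells (Homo sapiens) for inhibition, read by sulforhodamine B assay, with a stated time of 48 h (a higher number here means a weaker inhibitor of growth, a lower number a stronger inhibitor of growth), compound 1 (`O=C(Nc1cccc(-n2cc(-c3ccncc3)c(-c3ccc(Cl)c(O)c3)n2)c1)Nc1cccc(C(F)(F)F)c1`) gives 12000 nM, the highest of the three measured numbers, which makes it the weakest inhibitor of growth among them. Compound 3 (`COc1cc(-c2nn(-c3cccc(NC(=O)c4cccc(C(F)(F)F)c4)c3)cc2-c2ccncc2)ccc1Cl`) gives 3150 nM, and compound 2 (`COc1cc(-c2nn(-c3cccc(NC(=O)Nc4cc(C(F)(F)F)cc(C(F)(F)F)c4)c3)cc2-c2ccncc2)ccc1Cl`) gives 2060 nM. Both lie lower than compound 1 by more than the usual scatter. Each of them differs from compound 1 in more than one place, however, so the measured compounds offer no single-place step to reason from.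

Compound 4 (`O=C(Nc1cccc(-n2cc(-c3ccncc3)c(-c3ccc(Cl)c(O)c3)n2)c1)Nc1ccc(Cl)c(Cl)c1`) keeps the core of compound 1 and changes only the group on an amide-type nitrogen, with 3,4-dichlorophenyl in place of 3-(trifluoromethyl)phenyl on an amide-type nitrogen. Since compound 1 starts from the top of the measured range at 12000 nM, any shift is expected to be downward, and only a small one. The expected step is a 1.7-fold lower number from compound 1 to compound 4 (0.23 log units; within the scatter), which is not expected to clear the scatter clearly. Compound 4 is estimated at 7000 nM, with an expected range of 2500 nM to 18000 nM.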

Compound 4, concentration for total growth inhibition: 6400 nM
For compound 4 the middle estimate is 1.1-fold (0.04 log units) above the measured one, and the stated range covers the measured number.
By their numbers in this assay, from the lowest: compounds 2 and 3 (each within the scatter of the next); then compounds 4 and 1 (each within the scatter of the next).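

In this assay, going by these compounds alone, the first step that changes one place only lies on an amide-type nitrogen, where 3,4-dichlorophenyl in place of 3-(trifluoromethyl)phenyl gives a 1.9-fold lower number from compound 1 to compound 4 (0.27 log units; within the scatter) and so no difference that stands clear of the scatter. On the core of compound 1, then, this read-out does not tell these two groups apart at this position. The data shown offer no explanation for this result.

Still open, on these data alone, is whether a different group on that nitrogen, such as an unsubstituted phenyl, a pyridine ring or a plain alkyl chain, would move the number beyond the scatter. Within the data shown here, also open is whether a methoxy group in place of the hydroxyl on the core of compound 4, as the only change, would shift it.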